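The source may report more compounds than this note shows. Statements on the series, on what has been measured and on what is new or still open speak of the compounds shown alone.

Values so far in an ADME assay on microsomes from liver (Rattus norvegicus) for metabolic stability, read by LC-MS, in the presence of a further agent that is not named here; a higher number here means faster removal of the compound, a lower number slower removal:
- compound 1 `COc1cccnc1-c1nc2ccc(-c3nc4c(C)ncc(C)n4n3)cc2[nH]1` at 5.4 mL.min-1.g-1
- compound 2 `Cc1ncc(C)n2nc(-c3ccn4cc(-c5ccc(F)cc5Cl)nc4n3)nc12` at 11.5 mL.min-1.g-1
- compound 3 `Cc1ncc(C)n2nc(-c3ccc4nc(-c5ccco5)[nH]c4c3)nc12` at 26.3 mL.min-1.g-1

Compound 2 holds the middle place of the three, above compound 1 and below compound 3, with both gaps beyond the scatter. Compound 4 `Cc1ncc(C)n2nc(-c3ccn4cc(-c5ccccc5Br)nc4n3)nc12` departs from compound 2 by one change, 2-bromophenyl in place of 2-chloro-4-fluorophenyl on an aromatic carbon.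

For the measured compounds named here, no measured step covers this swap. The nearest in kind, with furan-2-yl in place of 3-methoxypyridin-2-yl, is a 4.9-fold higher number from compound 1 to compound 3 (0.69 log units; beyond the scatter) on the core of compound 1. That step involves other groups on another core, so it serves only as a loose upper guide to size. A step of that size is not expected here. In this assay the expectation is a slight lean upward from compound 2 at 11.5 mL.min-1.g-1 and nothing clearly beyond the scatter. The estimate means an expected 1.3-fold higher number from compound 2 to compound 4 (0.12 log units; within the scatter). For compound 4 the estimated value is 15 mL.min-1.g-1 with an expected range of 7 mL.min-1.g-1 to 30 mL.min-1.g-1.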

Compound 4, intrinsic clearance in microsomes: 1.8 mL.min-1.g-1
For compound 4 the middle estimate is 8.3-fold (0.92 log units) above the measured one; measured number below the stated range.
By their numbers in this assay, from the lowest: compound 4; then compound 1; then compound 2; then compound 3.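

In this assay, the group on an aromatic carbon of the five-membered aromatic ring on the core of compound 2 proves sensitive to a small change: 2-bromophenyl in place of 2-chloro-4-fluorophenyl gives a 6.4-fold lower number from compound 2 to compound 4 (0.81 log units; beyond the scatter). Both groups are one six-membered aromatic ring of carbon only with no net charge, so a swap that leaves these counted features unchanged still moves the number beyond the scatter, and this is the first step shown on this core. No measured evidence bears on the reason for this step.

Going by these compounds, the step exchanges chlorine for bromine and loses fluorine at once, so the share of each in the lower number stays open. Also open, on these data alone, is whether an amine or a nitrile on that phenyl ring would keep the number this low.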